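Quinazoline-diamine series: alkyl swap on the amine nitrogen

A few compounds are considered here, and "the series" means these few. Any claim that something is new, unique, unknown or untested is made for them only; others in the source may bear on it.

Within the data shown here, compound 1 `CNc1nc(NC2CCCC2)nc2ccccc12` is the only member of this set with a number in an ADME assay on J774.A1 cells (Mus musculus) for inhibition, read by MTT assay, with a stated time of 72 h; on this read-out lower numbers stand for an effect already at smaller amounts and higher numbers for an effect only at larger amounts of compound: compound 1 gives 39000 nM. For compound 2 `CNc1nc(NC(C)C)nc2ccccc12` the entry in this assay reads "not determined" (no result reported), and for compound 3 `CNc1nc(NCCO)nc2ccccc12` it reads "not determined" (no result reported), so compound 2 cannot be placed against compound 1 on the numbers shown. Compound 4 `CC(C)Nc1nc(NC(C)C)c2ccccc2n1` differs from compound 2 by isopropyl in place of methyl on a nitrogen on an aromatic ring. Among the measured compounds shown here, no step between measured compounds is known for this change, so its size cannot be read from the data; the expectation is a step no larger than the usual scatter in this assay, in no firm direction, with compound 1 as the only anchor for the series. Compound 4 is estimated at 40000 nM, expected between 15000 nM and 150000 nM.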

Compound 4, half-maximal effective concentration: > 30000 nM
Compound 4: a limit, no number (the forecaster's own chance of this, stated with the estimate: 30%); the middle value lies beyond the limit too.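

In this assay compound 4 reads > 30000 nM, a limit and not a number, and compound 2 has no result, so no step can be read between them. The compounds shown leave open what the change from methylamino to isopropylamino does to the read-out.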